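Side-chain swap from compound 3 to compound 4

The source may report more compounds than this note shows. Statements on the series, on what has been measured and on what is new or still open speak of the compounds shown alone.

Measured in an ADME assay on microsomes from liver (Mus musculus) for metabolic stability, read by LC-MS, using NADPH, with stated times of 10 min and 30 min, tested at 1 uM; on this read-out higher numbers stand for fast clearance and lower numbers for slow clearance:
compound 1 `COC(=O)C1=C(CN2CCOCC2=O)NC(c2nccs2)=NC1(C)c1ccc(F)cc1`: 80 mL/min/kg
compound 2 `COC(=O)C1=C(CN2CCC(F)(F)CC2)NC(c2nccs2)=NC1(C)c1ccc(F)cc1`: 88 mL/min/kg
compound 3 `COC(=O)C1=C(CN(C)C2(C(=O)O)CC2)NC(c2nccs2)=NC1(C)c1ccc(F)cc1`: 42 mL/min/kg

Compound 3 gives 42 mL/min/kg. The steps reaching it are a 1.9-fold lower number from compound 1 to compound 3 (0.28 log units; within the scatter) and a 2.1-fold lower number from compound 2 to compound 3 (0.32 log units; beyond the scatter), so only the second separates it from another compound.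

Compound 4 `COC(=O)C1=C(COC(C(=O)O)C(F)(F)F)NC(c2nccs2)=NC1(C)c1ccc(F)cc1` carries a group of 9 heavy atoms (3 carbon, 3 oxygen, 3 fluorine; no ring) in place of a group of 8 heavy atoms (5 carbon, 1 nitrogen, 2 oxygen; one three-membered non-aromatic ring of carbon only), on a saturated chain carbon bound to a double-bonded ring carbon. All three measured steps change this same place, and the third is a 1.1-fold higher number from compound 1 to compound 2 (0.04 log units; within the scatter). Going by the values given here, none is large, and no measured compound holds the entering group. A step beyond the scatter is therefore not expected in this assay. The expected step is a 1.1-fold lower number from compound 3 to compound 4 (0.02 log units; within the scatter). For compound 4 the estimated value is 40 mL/min/kg, with an expected range of 18 mL/min/kg to 78 mL/min/kg.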

Compound 4, clearance: 24 mL/min/kg
For compound 4 the middle estimate is 1.7-fold (0.22 log units) above the measured one, within the range that was stated.
By their numbers in this assay, from the lowest: compounds 4, 3, 1 and 2 (each within the scatter of the next, the first and the last beyond it).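

In this assay, going by these compounds alone, compound 4 is the first compound at this position on a saturated chain carbon bound to a double-bonded ring carbon to stand beyond the scatter from both compounds without a carboxylic acid, with a 3.3-fold lower number from compound 1 to compound 4 (0.52 log units; beyond the scatter) and a 3.7-fold lower number from compound 2 to compound 4 (0.56 log units; beyond the scatter). Compound 3 separates only from compound 2, so it goes against any simple link between the carboxylic acid and lower clearance, and a 1.8-fold lower number from compound 3 to compound 4 (0.24 log units; within the scatter) leaves compound 3 and compound 4 unordered. Nothing available explains these steps.

Open, from the compounds shown here alone, is whether a methyl group in place of the trifluoromethyl keeps the lower clearance of compound 4. Also open, going by these compounds, is how a primary amide or a tetrazole in place of the carboxylic acid would read.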